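Methoxy-for-hydroxy step on a pyrazole urea and amide series

The source may hold more compounds than are shown below. What is called first, only, known or untested is meant among the compounds shown, and "the series" means these compounds.

Measured so far:
compound 1 `O=C(Nc1cccc(-n2cc(-c3ccncc3)c(-c3cc(O)cc(Cl)c3)n2)c1)Nc1ccc(Cl)c(Cl)c1` gives -50.5% in a functional assay on SF-295 cells (Homo sapiens) for inhibition, read by sulforhodamine B assay, with a stated time of 48 h, tested at 10 uM; a lower number here means a stronger effect, a higher number a weaker effect of the compound at the concentration tested
compound 2 `COc1cc(Cl)cc(-c2nn(-c3cccc(NC(=O)Nc4ccc(Cl)c(Cl)c4)c3)cc2-c2ccncc2)c1` gives -2.42% in this assay
compound 3 `O=C(Nc1cccc(-n2cc(-c3ccncc3)c(-c3cc(O)cc(Cl)c3)n2)c1)c1cc(C(F)(F)F)cc(C(F)(F)F)c1` gives 15% in this assay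

Compound 1 and compound 2 differ only by methyl in place of hydrogen on an oxygen on an aromatic ring, and that change made the step of a number 48.1 percentage points higher from compound 1 to compound 2 (beyond the scatter). Compound 3 carries a different core; the difference between the two cores is not broken down here. Compound 3 stands highest of the three numbers, beyond the scatter from both compound 2 and compound 1.

Compound 4 `COc1cc(Cl)cc(-c2nn(-c3cccc(NC(=O)c4cc(C(F)(F)F)cc(C(F)(F)F)c4)c3)cc2-c2ccncc2)c1` is not yet measured. It differs from compound 3 by methyl in place of hydrogen on an oxygen on an aromatic ring, the same change made between compound 1 and compound 2, occurring twice among the compounds shown. Because a number 48.1 percentage points higher from compound 1 to compound 2 (beyond the scatter) was large and in the direction of a weaker effect, a step of the same sign is expected from compound 3 to compound 4, though likely smaller since compound 3 already starts at 15%. The expected step is a number 25 percentage points higher from compound 3 to compound 4 (beyond the scatter). For compound 4 the estimate in this assay is 40%, with a range from 15% to 70%.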

Compound 4, a percentage reported as activity, at one concentration (the size of the read-out at that concentration, not a potency): 42.1%
Compound 4: middle estimate off by 2.1 percentage points, on the low side, and the stated range covers the measured number.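

In this assay, the change from 3-chloro-5-hydroxyphenyl to 3-chloro-5-methoxyphenyl on the second core gives a number 27.1 percentage points higher from compound 3 to compound 4 (beyond the scatter), so on both cores shown, methyl in place of hydrogen on this oxygen moves the number toward a weaker effect. The direction carries from one core to the other, but the size does not: the same change on two cores in this assay, a number 48.1 percentage points higher (beyond the scatter) from compound 1 to compound 2 and a number 27.1 percentage points higher (beyond the scatter) from compound 3 to compound 4, 21 percentage points apart, beyond the scatter of two such steps. These two pairs show neither which part of the difference between the cores goes with the different step size nor whether the same direction would hold on a third core.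

Every compound shown carries either hydroxy or methoxy at this place, so it remains open how a longer chain on the oxygen, such as ethoxy, or an amine or a carboxylic acid in place of the hydroxy, would read in this assay. Also open, from the compounds shown here alone, is how the step behaves when the urea and the amide are exchanged with the rest of the molecule held fixed.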